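This account rests on a few compounds, and the source may have more. Where it says the series, first, only, none or still open, it means among the compounds named here.

Compound 1 `Nc1scc(CN2CCN(c3ccc(Cl)cc3Cl)CC2)c1C(=O)c1ccc(Cl)cc1` is one of three closely related compounds that share a core and differ only in the aryl group carried on the ring amine nitrogen. In a functional assay on CHO cells with adenosine receptor A1 (Homo sapiens) as the target, read by cAMP accumulation and immunoassay, with a stated time of 6 min, tested at 10 uM (a lower number here means a stronger effect, a higher number a weaker effect of the compound at the concentration tested), compound 1 gives -74%. Compound 2 `Nc1scc(CN2CCN(c3cccc(C(F)(F)F)c3)CC2)c1C(=O)c1ccc(Cl)cc1` gives -80% in this assay, and compound 3 `Nc1scc(CN2CCN(c3ccc(OC(F)(F)F)cc3)CC2)c1C(=O)c1ccc(Cl)cc1` gives -74%. On these numbers compound 1 stands level with compound 3, the two together being the highest of the three, with compound 2 the furthest away; the steps of a number 6 percentage points lower from compound 1 to compound 2 (within the scatter), no change at the digits printed from compound 1 to compound 3 (within the scatter) and a number 6 percentage points higher from compound 2 to compound 3 (within the scatter) are all small and none reaches beyond the usual scatter.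

Compound 4 `Nc1scc(CN2CCN(c3cccc(F)c3F)CC2)c1C(=O)c1ccc(Cl)cc1` is the next variation of the same kind: 2,3-difluorophenyl in place of 2,4-dichlorophenyl on an amine nitrogen in a ring. Every measured step here exchanges the aryl group on that same ring nitrogen, and each stayed within the scatter, so the same is expected for compound 4, namely no change at the digits printed from compound 1 to compound 4 (within the scatter). Compound 4 is therefore estimated to give -74% in this assay, expected to lie between -90% and -56%.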

Compound 4, a percentage reported as activity, at one concentration (the size of the read-out at that concentration, not a potency): -79%
For compound 4 the middle estimate is 5 percentage points above the measured one; the range from low to high includes it.
By their numbers in this assay, from the lowest: compounds 2, 4, 1 and 3 (each within the scatter of the next).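

In this assay, the 2,3-difluorophenyl group on the ring amine nitrogen stays within the scatter of all three earlier aryl groups: a number 5 percentage points lower from compound 1 to compound 4 (within the scatter), a number 5 percentage points lower from compound 3 to compound 4 (within the scatter) and a number 1 percentage points higher from compound 2 to compound 4 (within the scatter). The change replaces two chlorine atoms with two fluorine atoms and moves them to a different arrangement on the phenyl ring, yet the read-out stays level with the other three. The four compounds therefore show no order among themselves at this position, and nothing given here bears on why that is so.

On these data alone, all four compounds carry a halogen-containing phenyl group on that nitrogen, so it remains open whether the read-out would hold with a simple methyl, a longer alkyl chain or a carboxylic acid there. As far as these compounds go, it is also open whether a phenyl group carrying an amine or a hydroxyl would fall within the same range.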